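The source may hold more compounds than are shown below. What is called first, only, known or untested is meant among the compounds shown, and "the series" means these compounds.

Measured so far:
compound 1 `Fc1cccc(-c2cn([C@@H]3CN4CCC3CC4)nn2)c1` gives 519 nM
compound 2 `Fc1ccc(COc2cccc(-c3cn(C4CN5CCC4CC5)nn3)c2)cc1` gives 1010 nM

Both numbers come from an assay on HEK293 cells for displacement of a labelled ligand from Neuronal acetylcholine receptor; alpha4/beta2 (Homo sapiens), read by scintillation counting, with a stated time of 120 min; a lower number here means a stronger inhibitor, a higher number a weaker inhibitor. Compound 2 holds the higher of the two numbers; its nearest neighbour is compound 1, and the gap between them lies within the scatter, so the two cannot be ordered. The step from compound 2 to compound 3 `Fc1ccc(COc2cccc(-c3cn([C@@H]4CN5CCC4CC5)nn3)c2)cc1` changes no atom or bond: the two compounds have the same atoms and bonds; at least one stereo element is drawn with a configuration in one of them and without one in the other: 1 of 3 stereo elements differ; a stereocentre at a saturated ring carbon is drawn without a configuration in compound 2 and S in compound 3. Among the compounds with values here, no step between two measured compounds separates a drawn configuration from an undrawn one, so the size of this kind of step is not known from the data. Compound 1, which carries the same drawn configuration at that centre, gives 519 nM, which suggests that this configuration is tolerated. The author expects a modest step toward a lower number, a 1.7-fold lower number from compound 2 to compound 3 (0.23 log units; within the scatter), not clearly beyond the scatter. Compound 3 is therefore estimated at 600 nM, with a range from 250 nM to 1500 nM.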

Compound 3, inhibition constant: 537 nM
The estimate for compound 3 lay 1.1-fold (0.05 log units) above the measured number, and the stated range covers the measured number.
By their numbers in this assay, from the lowest: compounds 1, 3 and 2 (each within the scatter of the next).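

Within the data shown here, the step to compound 3 gives the first reading of this stereocentre: in this assay the drawn S configuration comes with a 1.9-fold lower number from compound 2 to compound 3 (0.27 log units; within the scatter) and so cannot be told apart from the undrawn form, where all that separates the two is this: the fact that one of compounds 2 and 3 is drawn with a defined configuration and the other without, at the place where they differ. Compound 1 and compound 2 differed in more than one place, whereas compound 1 and compound 3 share the drawn configuration and differ in one place only. For (4-fluorobenzyl)oxy in place of fluoro on an aromatic carbon, the data show a 1.0-fold higher number from compound 1 to compound 3 (0.01 log units; within the scatter) and so no readable effect of that exchange. The compounds shown leave open how the R configuration at this centre would read. They also leave open whether an amine or a carboxylic acid on that aromatic carbon would stay within the same range.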